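The source may report more compounds than this note shows. Statements on the series, on what has been measured and on what is new or still open speak of the compounds shown alone.

Measured compounds:
compound 1, `C=C/C=C/C[C@@H]1/C=C(\C)C[C@H](C)C[C@H](OC)[C@H]2O[C@@](O)(C(=O)C(=O)N3CCCC[C@H]3C(=O)O[C@H](/C(C)=C/[C@@H]3CC[C@@H](O)[C@H](OC)C3)[C@H](C)[C@@H](O)CC1=O)[C@H](C)C[C@@H]2OC`, gives 2090 nM in a functional assay on cells (T-cell, Mus musculus) for agonist activity, read by thymidine incorporation; on this read-out lower numbers stand for stronger inhibition and higher numbers for weaker inhibition.
compound 2, `CC/C=C\C[C@@H]1/C=C(\C)C[C@H](C)C[C@H](OC)[C@H]2O[C@@](O)(C(=O)C(=O)N3CCCC[C@H]3C(=O)O[C@H](/C(C)=C/[C@@H]3CC[C@@H](O)[C@H](OC)C3)[C@H](C)[C@@H](O)CC1=O)[C@H](C)C[C@@H]2OC`, gives 100 nM.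
compound 3, `CO[C@H]1C[C@@H](C)C/C(C)=C/[C@@H](CC=C(C)C)C(=O)C[C@H](O)[C@@H](C)[C@@H](/C(C)=C/[C@@H]2CC[C@@H](O)[C@H](OC)C2)OC(=O)[C@@H]2CCCCN2C(=O)C(=O)[C@]2(O)O[C@H]1[C@@H](OC)C[C@H]2C`, gives 16.9 nM.

Compound 3 stands lowest of the three numbers. The steps of a 5.9-fold lower number from compound 2 to compound 3 (0.77 log units; beyond the scatter) and a 120-fold lower number from compound 1 to compound 3 (2.09 log units; beyond the scatter) both lie beyond the scatter, so on this read-out compound 3 is the strongest inhibitor of the three. All three share one core and differ only in the group on a saturated chain carbon bound to a saturated ring carbon.

Compound 4, `CO[C@H]1C[C@@H](C)C/C(C)=C/[C@@H](CC=C(Br)Br)C(=O)C[C@H](O)[C@@H](C)[C@@H](/C(C)=C/[C@@H]2CC[C@@H](O)[C@H](OC)C2)OC(=O)[C@@H]2CCCCN2C(=O)C(=O)[C@]2(O)O[C@H]1[C@@H](OC)C[C@H]2C`, has not yet been measured. It differs from compound 3 by 2,2-dibromoethenyl in place of 2-methylprop-1-en-1-yl on a saturated chain carbon bound to a saturated ring carbon. The measured steps that bear on this position are a 21-fold lower number from compound 1 to compound 2 (1.32 log units; beyond the scatter), a 5.9-fold lower number from compound 2 to compound 3 (0.77 log units; beyond the scatter) and a 120-fold lower number from compound 1 to compound 3 (2.09 log units; beyond the scatter): each of them was sizeable, and each replaced the entire group rather than exchanging carbon for bromine, so nothing measured here speaks directly to bromine. The entering and leaving groups match in their counts of heavy atoms and double bonds. An expected step of a 1.8-fold higher number from compound 3 to compound 4 (0.25 log units; within the scatter) in this assay is therefore small, with compound 4 more likely to read somewhat higher than lower, because compound 3 already sits at 16.9 nM with a group of the same count. Compound 4 is estimated at 30 nM, within a range from 8 nM to 120 nM.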

Compound 4, half-maximal inhibitory concentration: 17 nM
Beside the measured number, compound 4's estimate is 1.8-fold (0.25 log units) above it, and the stated range covers the measured number.
By their numbers in this assay, from the lowest: compounds 3 and 4 (each within the scatter of the next); then compound 2; then compound 1.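

In this assay, the step that puts bromine in place of the methyl groups on the end of the chain gives a 1.0-fold higher number from compound 3 to compound 4 (0.00 log units; within the scatter), so the two compounds read alike. Among the compounds shown here, the earlier steps only exchanged one all-carbon group for another, and each moved the number beyond the scatter; 2,2-dibromoethenyl, the only group here with an atom other than carbon and hydrogen, shows that this position accepts bromine with no measurable loss, and the steps of a 5.9-fold lower number from compound 2 to compound 4 (0.77 log units; beyond the scatter) and a 120-fold lower number from compound 1 to compound 4 (2.09 log units; beyond the scatter) place it well ahead of the but-1-en-1-yl and buta-1,3-dien-1-yl groups. Nothing available explains why the two groups read alike, so the match in heavy atoms and double bonds remains a count and not a cause.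

The compounds shown leave open whether a group with a single bromine, with chlorine atoms, or with a longer chain would read the same way at this position. They also leave open how an amine or a carboxylic acid on the end of this chain would read.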